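The source may hold more compounds than are shown below. What is called first, only, known or untested is meant among the compounds shown, and "the series" means these compounds.

Compound 1, `CCNC(=O)CCC(NS(=O)(=O)c1cc(Cl)ccc1Cl)C(=O)NCC`: 12.9%
Compound 2, `CCCCCCNC(=O)CCC(NS(=O)(=O)c1cc(Cl)ccc1Cl)C(=O)NCCCCCC`: 12.4%
Compound 3, `O=C(CCC(NS(=O)(=O)c1cc(Cl)ccc1Cl)C(=O)Nc1ccccc1)Nc1ccccc1`: 22.9%

Three compounds sharing one core, all measured in a functional assay on IMR-32 cells (Homo sapiens) for cytotoxicity, read by MTT assay, tested at 60 ug/mL (a higher number here means more inhibition at the concentration tested (going by the name of the read-out), a lower number less inhibition), give numbers that lie close together. Compound 1 holds the second highest of the three numbers, but its nearest neighbour, compound 2, differs from it only by an amount within the scatter, and compound 3, the furthest of the three, is also within the scatter of it. The three numbers therefore cannot be told apart, and the inhibition in this assay cannot be called higher or lower for one compound than for another on these data.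

The unmeasured compound 4, `CCNC(=O)CCC(NS(=O)(=O)c1cc(C)ccc1Cl)C(=O)NCC`, follows from compound 1 by a single change on the aromatic ring: methyl in place of chloro on an aromatic carbon. Going by the values given here, no step between measured compounds isolates such a change, so there is nothing to lean on beyond the fact that compound 1, compound 2 and compound 3 all land in the same region of this assay despite quite different substituents on the amides.

With that in view, compound 4 is expected to stay where compound 1 stands, the estimated step being a number 0.1 percentage points higher from compound 1 to compound 4 (within the scatter), that is, none beyond the scatter. Compound 4 is estimated to give 13% in this assay, within a range from 3% to 25%.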

Compound 4, a percentage reported as inhibition, at one concentration (the size of the read-out at that concentration, not a potency): 31.8%
Estimate against measurement, compound 4: 18.8 percentage points below; measured number above the stated range.
By their numbers in this assay, from the lowest: compounds 2, 1, 3 and 4 (each within the scatter of the next, the first and the last beyond it).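

In this assay, replacing the 2,5-dichlorophenyl group of compound 1 with the 2-chloro-5-methylphenyl group, while leaving the rest of the structure untouched, gives a number 18.9 percentage points higher from compound 1 to compound 4 (beyond the scatter). Going by these compounds alone, this is the first comparison here that isolates a single place, and it shows that the aromatic carbon para to a chloro group and meta to a large group is not indifferent to what it carries. The exchange swaps one heavy atom for one heavy atom and alters neither the counted hydrogen-bond donors and acceptors nor the net charge, yet the step lies beyond the usual scatter, though nothing available accounts for it.

As far as these compounds go, it remains open whether the same exchange would carry over to the hexyl amides of compound 2 or the phenyl amides of compound 3, and whether the remaining chloro group contributes to the reading. Also open, from the compounds shown here alone, is what a methoxy group, a fluoro group or a bare hydrogen at this position would give in this assay, and, with the read-out taken at a single concentration, how these compounds would compare in potency.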